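Hydrazone aryl exchange on the shared core: compound 3

The source may hold more compounds than are shown below. What is called first, only, known or untested is meant among the compounds shown, and "the series" means these compounds.

The series shares the core of compound 1 `O=C(N/N=C/c1cccc(Cl)c1)c1cccnc1Nc1cccc(C(F)(F)F)c1` and varies only the aryl group on a carbon with a double bond to nitrogen. In a functional assay on the whole organism (strain Wistar) for inhibition, with Rattus norvegicus as the target, read by paw edema, with a stated time of 4 h, at a dose of 10 mg/kg by the intraperitoneal route (a higher number here means more inhibition at the dose given (going by the name of the read-out), a lower number less inhibition), compound 1 gives 40.4%. Going by the values given here, compound 2 `COc1ccc(/C=N/NC(=O)c2cccnc2Nc2cccc(C(F)(F)F)c2)c(OC)c1` gives 19.8% in this assay, the lower of the two numbers measured so far; the only measured step, a number 20.6 percentage points lower from compound 1 to compound 2 (beyond the scatter), is the one that separates them.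

Compound 3 `O=C(N/N=C/c1ccncc1)c1cccnc1Nc1cccc(C(F)(F)F)c1` is the next change: pyridin-4-yl in place of 2,4-dimethoxyphenyl on a carbon with a double bond to nitrogen. Among the compounds with values here, no measured step covers an exchange of this kind, since the one step on record swaps one six-membered ring of carbon only for another. That step shows that the identity of this aryl group moves the read-out in this assay by a modest amount, so a step of similar size is plausible here, with no firm guide to its direction; the expected step is a number 10.2 percentage points higher from compound 2 to compound 3 (beyond the scatter), leaning back toward the value of compound 1. Compound 3 is therefore estimated at 30% in this assay, within a range of 12% to 50%.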

Compound 3, a percentage reported as inhibition, in the whole organism at one dose (the size of the read-out at that dose, not a potency): 45.9%
Estimate against measurement, compound 3: 15.9 percentage points below, within the range that was stated.
By their numbers in this assay, from the lowest: compound 2; then compounds 1 and 3 (each within the scatter of the next).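

In this assay, the exchange on the carbon with a double bond to nitrogen gives a number 26.1 percentage points higher from compound 2 to compound 3 (beyond the scatter), so a six-membered aromatic ring with a hetero atom can restore the read-out lost with 2,4-dimethoxyphenyl. The other new step, a number 5.5 percentage points higher from compound 1 to compound 3 (within the scatter), lies within the scatter, so pyridin-4-yl and 3-chlorophenyl cannot be told apart at this position, and only compound 2 stands apart, with its steps to both other compounds beyond the scatter. Nothing available explains these steps.

The three aryl groups do not show whether the lower number of compound 2 goes with the methoxy groups as such or with their number, which a phenyl ring bearing a single methoxy group or an unsubstituted phenyl ring would help to separate. Also open, on these data alone, is how this position responds to a phenyl ring carrying an amine or a carboxylic acid, and, since each number is the size of the read-out at a single dose, how the compounds compare in potency.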